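From Compound 2 to Compound 3 at a Cytotoxicity Limit

A few compounds are considered here, and "the series" means these few. Any claim that something is new, unique, unknown or untested is made for them only; others in the source may bear on it.

In a toxicity assay on Huh-7 cells (Homo sapiens) for cytotoxicity, read by CCK-8 assay, with a stated time of 24 h (a higher number here means that more compound is tolerated, a lower number that less compound is tolerated), compound 2 `Oc1cc2oc(-c3ccccc3)cc(=S)c2c(O)c1O` gives > 100000 nM, which is a limit of the assay and not a number. In this assay, compound 1 `Oc1c(O)c(O)c2c(=S)cc(-c3ccccc3)oc2c1-c1cccc(F)c1` gives > 100000 nM, which is also a limit. Together they form (the limit of > 100000 nM in this assay, at which 2 of the 2 values shown sit).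

Compound 3 `Oc1c(O)c(O)c2c(=S)cc(-c3ccccc3)oc2c1-c1ccc(C(F)(F)F)cc1` departs from compound 2 by 4-(trifluoromethyl)phenyl in place of hydrogen on an aromatic carbon, with 4-(trifluoromethyl)phenyl in place of hydrogen on an aromatic carbon. For the measured compounds named here, the one measured step bearing on this change is a step that the two limits leave unreadable from compound 1 to compound 2, which exchanges 3-fluorophenyl for hydrogen and gives no readable size. No step beyond the scatter is therefore expected in this assay, and no direction can be assigned. The estimate corresponds to a number no higher from compound 2 to compound 3 (the limit leaves the size open), an expected step that stays within the scatter. For compound 3, the estimated half-maximal cytotoxic concentration is 100000 nM, with an expected range from 50000 nM to 200000 nM.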

Compound 3, half-maximal cytotoxic concentration: > 100000 nM
Compound 3: no number, only a limit; the forecaster's own chance of this, stated with the estimate: 80%; the middle value lies on the limit itself.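

In this assay compound 3 gives > 100000 nM, a limit and not a number, so neither its step from compound 1 nor its step from compound 2 can be read. The compounds shown leave open what concentration of compound 1, compound 2 or compound 3 would prove cytotoxic, and whether hydrogen, 3-fluorophenyl or 4-(trifluoromethyl)phenyl at this place changes that concentration.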